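Dropping a hydroxy group from compound 1

The source may report more compounds than this note shows. Statements on the series, on what has been measured and on what is new or still open speak of the compounds shown alone.

Measured compounds:
Compound 1 `C=C1C(=O)C2=C3[C@H]1[C@H]1OC(=O)C(=C)[C@@H]1CC[C@@]3(O)CC[C@]21C(=O)C[C@H]2C(=C)CC[C@H]3C(=C)C(=O)O[C@@H]3[C@H]21`: > 10000 nM
Compound 2 `C=C1C(=O)O[C@@H]2[C@@H]3C4=C(C(=O)[C@H]3CO)[C@]3(CC[C@]4(O)CC[C@@H]12)C(=O)C[C@H]1C(=C)CC[C@H]2C(=C)C(=O)O[C@@H]2[C@H]13`: > 10000 nM

In a functional assay on HeLa cells (Homo sapiens) for cytotoxicity, read by CellTiter-Glo, with a stated time of 72 h (a higher number here means a weaker inhibitor, a lower number a stronger inhibitor), compound 1 gives only a limit, > 10000 nM. Compound 2 likewise gives only a limit, > 10000 nM. For the measured compounds named here, both values sit at the limit of > 10000 nM in this assay, at which 2 of the 2 values shown sit, so compound 1 stands at the edge of what this assay reports, with no number beneath it and no measured step to lean on.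

Compound 3 `C=C1C(=O)C2=C3[C@H](CC[C@H]4C(=C)C(=O)O[C@@H]4[C@@H]13)CC[C@]21C(=O)C[C@H]2C(=C)CC[C@H]3C(=C)C(=O)O[C@@H]3[C@H]21` is the next compound. It differs from compound 1 by hydrogen in place of hydroxy on a saturated ring carbon. With both measured compounds resting at a limit, there is no measured change to set the size of this step. The step that the limit leaves unreadable from compound 1 to compound 3 is expected to be none beyond the scatter, because compound 1 sits at the limit of > 10000 nM in this assay, at which 2 of the 2 values shown sit, and nothing shown pulls the new compound away from it. Compound 3 is therefore expected to give 15000 nM, within a range from 5000 nM to 50000 nM, most probably reported again only as a limit.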

Compound 3, half-maximal inhibitory concentration: > 10000 nM
Compound 3 was reported as a limit; the forecaster's own chance of this, stated with the estimate: 70%; the middle value lies beyond the limit too.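

No step can be read from compound 1 to compound 3, since both give only a limit in this assay rather than a number: the limit of > 10000 nM in this assay, at which 3 of the 3 values shown sit. The compounds shown leave open whether swapping hydroxy for hydrogen changes cytotoxicity at all, and what structural change would bring a measurable value.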